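Swapping the amide cap on a potent aldosterone synthase inhibitor

The source may report more compounds than this note shows. Statements on the series, on what has been measured and on what is new or still open speak of the compounds shown alone.

Measured so far:
- Compound 1, `CCS(=O)(=O)N1CCC(c2cncc(N3C(=O)c4ccc(Cl)cc4C3(C)C)c2)CC1`: 3 nM
- Compound 2, `CC(=O)N[C@@H]1CCCc2c1cncc2N1CCc2cc(Cl)ccc2C1=O`: 54 nM
- Compound 3, `CCC(=O)N[C@@H]1CCCc2c1cncc2N1C(=O)c2ccc(Cl)cc2[C@@H]1C`: 6 nM

Of the compounds shown here, three have been tested in an assay on cells for inhibition of cytochrome P450 11B2, mitochondrial (Homo sapiens), read by HTRF; a lower number here means a stronger inhibitor, a higher number a weaker inhibitor. Compound 1 gives the lowest number of the three: compound 3 sits close by, within the usual scatter, so the two cannot be told apart; compound 2 lies clearly further off, beyond the scatter, with the weakest result of the set.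

The next compound, compound 4, `CC(=O)N1CCC(c2cncc(N3C(=O)c4ccc(Cl)cc4C3(C)C)c2)CC1`, keeps the whole core of compound 1 and changes only the cap on the ring nitrogen: acetyl in place of ethylsulfonyl on an amine nitrogen in a ring. For the measured compounds named here, no pair of measured compounds shows this change, so its effect has to be guessed from the fact that compound 1 is already very strong and that the rest of the molecule is untouched. The expected change is a 2.0-fold higher number from compound 1 to compound 4 (0.30 log units; within the scatter), a small step most likely toward a slightly higher number and not beyond the scatter.

Compound 4 is therefore expected to come out near 6 nM in this assay, within a range from 2 nM to 20 nM.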

Compound 4, half-maximal inhibitory concentration: 5 nM
Compound 4: the middle estimate sits 1.2-fold (0.08 log units) above what was measured; the range from low to high includes it.
By their numbers in this assay, from the lowest: compounds 1, 4 and 3 (each within the scatter of the next); then compound 2.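

For the compounds shown here, replacing ethylsulfonyl with acetyl on this amine nitrogen in a ring gives a 1.7-fold higher number from compound 1 to compound 4 (0.22 log units; within the scatter) in this assay and is the first one-place comparison in the set. At this position, the two caps cannot be told apart, even though acetyl has fewer heavy atoms, no sulfur and one hydrogen-bond acceptor fewer. On the core of compound 1, then, a sulfonyl cap is not needed for a low number in this measurement, and nothing available explains why the two caps read alike.

Still open, going by these compounds, is whether this position stays as forgiving with a quite different group, such as a bare amine with no cap, a longer acyl chain or a carboxylic acid. One pair also cannot show whether the same swap would behave alike on another core.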